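Adding a third methoxy to the dimethoxy analogue

The compounds below may be only part of what the source reports. "The series", "measured", "known", "first", "only" and "open" are said of these compounds alone.

Compound 1 `COc1ccc(C2=N/C(=C\c3cccnc3)C(=O)O2)cc1Br` gives 32% in an assay on isolated protein for inhibition of Death-associated protein kinase 3 (Homo sapiens), tested at 1 uM; on this read-out lower numbers stand for a weaker effect and higher numbers for a stronger effect at the one concentration tested.
Compound 2 `O=C1OC(c2cccc([N+](=O)[O-])c2)=N/C1=C\c1ccncc1` gives 0% in this assay.
Compound 3 `COc1ccc(C2=N/C(=C\c3cccnc3)C(=O)O2)cc1OC` gives 14% in this assay.

Compound 3 stands second highest of the three numbers, beyond the scatter above compound 2 and beyond the scatter below compound 1. Compound 4 `COc1cc(C2=N/C(=C\c3cccnc3)C(=O)O2)cc(OC)c1OC` differs from compound 3 by methoxy in place of hydrogen on an aromatic carbon. Among the measured compounds shown here, the one measured step that bears on it is the change from bromo to methoxy, a number 18 percentage points lower from compound 1 to compound 3 (beyond the scatter), a modest loss. Adding a further methoxy is a different change, so the step is expected to be small, at most a modest loss or none beyond the scatter. Compound 4 is therefore estimated at 8%, within 0% to 25%, a step of a number 6 percentage points lower from compound 3 to compound 4 (within the scatter) in this assay.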

Compound 4, a percentage reported as inhibition, at one concentration (the size of the read-out at that concentration, not a potency): 26%
The estimate for compound 4 lay 18 percentage points below the measured number; the measured number lies above the stated range.
By their numbers in this assay, from the lowest: compound 2; then compound 3; then compounds 4 and 1 (each within the scatter of the next).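

In this assay the methoxy entering in place of hydrogen, ortho to a methoxy group, gives a number 12 percentage points higher from compound 3 to compound 4 (beyond the scatter) and so shows that this ring position accepts an added group with a gain. The earlier step, a number 18 percentage points lower from compound 1 to compound 3 (beyond the scatter), exchanged one group for another and could not show what filling a position that held only hydrogen would do. Nothing shown here accounts for the gain. As far as these compounds go, whether an amine, a hydroxyl or a longer chain such as ethoxy at this position would give the same gain remains open.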